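The source may hold more compounds than are shown below. What is called first, only, known or untested is meant among the compounds shown, and "the series" means these compounds.

Compound 1 `COc1ccc(CCc2nc3cc(-c4c(C)noc4C)ccc3n2[C@H]2CC[C@H](OC)CC2)cc1Cl`: 97 nM
Compound 2 `COc1ccc(CCc2nc3cc(-c4c(C)noc4C)ccc3n2[C@H]2CC[C@H](O)CC2)cc1Cl`: 48 nM

Both numbers come from an assay on isolated protein for inhibition of histone acetyltransferase p300 (Homo sapiens), read by AlphaLISA, with a stated time of 20 min; a higher number here means a weaker inhibitor, a lower number a stronger inhibitor. Compound 2 holds the lowest of the two numbers; its nearest neighbour is compound 1, and the step of a 2.0-fold lower number from compound 1 to compound 2 (0.31 log units; beyond the scatter) separates them, beyond the scatter. Compound 3 `COc1ccc(CCc2nc3cc(-c4c(C)noc4C)ccc3n2C2CCC(F)(F)CC2)cc1Cl` differs from compound 2 by 4,4-difluorocyclohexyl in place of 4-hydroxycyclohexyl on an aromatic nitrogen. Going by the values given here, no measured step matches this change directly; the only step that bears on it is a 2.0-fold lower number from compound 1 to compound 2 (0.31 log units; beyond the scatter), which shows that exchanging methyl for hydrogen on that oxygen lowered the number modestly. Compound 3 gives up both the donor and the acceptor of that group, so the expectation is a move back upward, plausibly at or somewhat past the number of compound 1, though the size is uncertain. The estimate for compound 3 in this assay is 120 nM, within 50 nM to 300 nM. The expected step is a 2.5-fold higher number from compound 2 to compound 3 (0.40 log units; beyond the scatter).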

Compound 3, half-maximal inhibitory concentration: 83 nM
Beside the measured number, compound 3's estimate is 1.4-fold (0.16 log units) above it, within the range that was stated.
By their numbers in this assay, from the lowest: compounds 2, 3 and 1 (each within the scatter of the next, the first and the last beyond it).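

In this assay the aromatic nitrogen tolerates a cyclohexyl group with no oxygen: replacing 4-hydroxycyclohexyl gives a 1.7-fold higher number from compound 2 to compound 3 (0.24 log units; within the scatter) and replacing 4-methoxycyclohexyl gives a 1.2-fold lower number from compound 1 to compound 3 (0.07 log units; within the scatter) as the two readings of this change. The earlier step on the oxygen suggested that this group could move the number, yet 4,4-difluorocyclohexyl, with 0 hydrogen-bond donors and 0 hydrogen-bond acceptors, leaves compound 3 within the scatter of both compound 1 and compound 2, so neither the hydroxyl nor the methoxy group is needed for a number in this range. No evidence on hand bears on the reason for this result.

Still open, going by these compounds, is how a cyclohexyl group carrying an amine or a carboxylic acid in place of the hydroxyl would read. Also open, on these data alone, is whether an open alkyl chain on that nitrogen would hold the number.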